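Replacing phenyl with pyridin-2-yl on an amide nitrogen

The source may report more compounds than this note shows. Statements on the series, on what has been measured and on what is new or still open speak of the compounds shown alone.

Measured in a functional assay on Bel-7402 cells (Homo sapiens) for inhibition, read by MTT assay, with a stated time of 24 h, tested at 10 ug/mL; on this read-out lower numbers stand for less inhibition of growth and higher numbers for more inhibition of growth at the one concentration tested:
Compound 1 `O=C(CCCCC1CCSS1)Nc1ccccn1` gives 5.77%
Compound 2 `O=C(CCCCC(S)CCS)Nc1ccccc1` gives 3.72%

Both measured compounds show little inhibition of growth at the single concentration tested. The value of compound 2 lies within the usual scatter of the value of compound 1, so the two numbers cannot be told apart.

The account now turns to compound 3 `O=C(CCCCC(S)CCS)Nc1ccccn1`, which differs from compound 2 in one place: it has pyridin-2-yl in place of phenyl on an amide-type nitrogen. Within the data shown here, no measured pair of compounds isolates this change, so the data give no direct guide to its size. With compound 1 at 5.77% and compound 2 at 3.72%, the readings so far stay low, and no step beyond the scatter is expected in either direction in this assay. The estimate is a number 2.3 percentage points higher from compound 2 to compound 3 (within the scatter), which is expected to remain within the scatter. For compound 3 the expected value is 6%, with an estimated range from 1% to 16%.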

Compound 3, percent growth inhibition at one concentration: "not active" (no number reported)
Nothing numeric was reported for compound 3, and the estimate cannot be compared.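

In this assay, among these compounds, compound 3 is reported only as not active, without a number, so no step from compound 2 to compound 3 can be read. The compounds shown leave open what size of effect, if any, pyridin-2-yl in place of phenyl on an amide-type nitrogen has on inhibition of growth. Nothing shown here bears on the reason for this result.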